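Removing the Methyl from the Ring Nitrogen of Compound 2

This account rests on a few compounds, and the source may have more. Where it says the series, first, only, none or still open, it means among the compounds named here.

Measured compounds:
compound 1, `COc1cc(/C=C/C(=O)NCCn2c(C)cc3ccccc32)cc(OC)c1`: 3.4 nM
compound 2, `COc1cc(/C=C/C(=O)NCc2c(C)n(C)c3ccccc23)cc(OC)c1OC`: > 1000 nM
compound 3, `Cc1cc2ccccc2n1CCNC(=O)/C=C/c1ccc(OCCCO)cc1`: 11.8 nM

Three compounds carrying the same cinnamamide linked to a methyl-bearing indole have been tested in an assay on C6 cells for antagonist activity at prostaglandin E2 receptor EP2 subtype (Homo sapiens), read by TR-FRET, with stated times of 10 min and 40 min, tested at 1 uM; on this read-out lower numbers stand for stronger inhibition and higher numbers for weaker inhibition. In this assay compound 1 gives 3.4 nM and compound 3 gives 11.8 nM, the two lying within the usual scatter of each other. Compound 2 stands apart: in this assay compound 2 reaches only > 1000 nM, which is a limit of the assay and not a number. Among the values shown this is the limit of > 1000 nM in this assay, at which 1 of the 3 values shown sits, so no step between compound 2 and either of the others can be sized.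

The next compound, compound 4, `COc1cc(/C=C/C(=O)NCc2c(C)[nH]c3ccccc23)cc(OC)c1OC`, differs from compound 2 in one place: hydrogen in place of methyl on an aromatic nitrogen. For the measured compounds named here, no measured pair reports what such a change does in this assay, so the direction and size of the step rest on expectation alone. With compound 2 already at a limit, the account expects compound 4 to remain weak, with a step that the limit leaves unreadable from compound 2 to compound 4 that may well be within the scatter. For compound 4 the expected antagonist equilibrium constant is 1500 nM, estimated to fall between 300 nM and 6000 nM.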

Compound 4, antagonist equilibrium constant: > 1000 nM
Compound 4: no number, only a limit; the forecaster's own chance of this, stated with the estimate: 60%; the middle value is on the limit's open side.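

In this assay compound 4 stands at a limit of the assay, not at a number, just as compound 2 does, so no step between the two can be read: the limit of > 1000 nM in this assay, at which 2 of the 4 values shown sit.

The compounds shown leave open how far past that limit each of the two lies, and what hydrogen in place of methyl on an aromatic nitrogen does in this assay.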